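The source may report more compounds than this note shows. Statements on the series, on what has been measured and on what is new or still open speak of the compounds shown alone.

Measured in a functional assay on BXPC-3 cells (Homo sapiens) for inhibition, read by XTT assay, with a stated time of 72 h; on this read-out lower numbers stand for stronger inhibition and higher numbers for weaker inhibition:
- compound 1 `CCCCCCCC/C=C\CCCCCCCCOC[C@@H]1CCCN1C(=O)OC(C)(C)C`: > 100000 nM, a limit
- compound 2 `CCCCCCCC/C=C/CCCCCCCCOC[C@@H]1CCCN1C(=O)OC(C)(C)C`: > 100000 nM, a limit
- compound 3 `CCCCCCCC/C=C\CCCCCCCCOC[C@@H]1CCCN1`: 5300 nM

Within the data shown here, compound 3 holds the only actual number in this small set. The other two results stand at the limit of > 100000 nM in this assay, at which 2 of the 3 values shown sit.

The next comparison is with compound 4 `CCCCCCCC/C=C/CCCCCCCCOC[C@@H]1CCCN1`. The structural change is the two compounds have the same atoms and bonds and differ only in configuration as drawn: 1 of 2 stereo elements differ; a double bond is drawn Z in compound 3 and E in compound 4. Among the measured compounds shown here, the nearest precedent is the pair of compound 1 and compound 2, given (the fact that compounds 1 and 2 differ only in the configuration as drawn). That pair shows a step that the two limits leave unreadable from compound 1 to compound 2, so it gives no size or direction for the double-bond change.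

For the measured compounds named here, the only readable step is an at least 18-fold lower number from compound 1 to compound 3 (1.27 log units; beyond the scatter). It is large, but it concerns hydrogen in place of tert-butoxycarbonyl on an amine nitrogen in a ring, not the double bond. Compound 4 shares that ring hydrogen with compound 3, so a number rather than a limit is expected in this assay.

With no measured size for the double-bond change in a readable pair, no step beyond the scatter is expected, and no direction is favoured. The expected result is a 1.1-fold lower number from compound 3 to compound 4 (0.03 log units; within the scatter). For compound 4 the estimated value is 5000 nM, with an expected range from 2000 nM to 15000 nM.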

Compound 4, half-maximal inhibitory concentration: 5300 nM
Compound 4: middle estimate off by 1.1-fold (0.03 log units), on the low side; measured number inside the range.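

In this assay, among these compounds, the double-bond change can now be read for the first time, on the cores with the free ring amine: the step is no change at the digits printed from compound 3 to compound 4 (within the scatter), so the Z and E drawings are not told apart by this read-out at this stage of the series. The exchange of tert-butoxycarbonyl for hydrogen on the ring nitrogen now also appears on the E chain, as an at least 18-fold lower number from compound 2 to compound 4 (1.27 log units; beyond the scatter), so the gain seen on the Z chain is not confined to that geometry, although its two sizes cannot be compared: the same change on two cores in this assay, an at least 18-fold lower number (1.27 log units; beyond the scatter) from compound 1 to compound 3 and an at least 18-fold lower number (1.27 log units; beyond the scatter) from compound 2 to compound 4; the limit leaves it open whether they differ. The step between compound 1 and compound 2 still cannot be read, since both values are limits.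

Open, from the compounds shown here alone, is whether the double bond itself matters, which a fully saturated chain or a shorter or longer chain on the same core would address. Also open, going by these compounds, is how much of the gain depends on the free ring nitrogen hydrogen, which a methyl or acetyl group on that nitrogen would test, and how the result changes with the opposite configuration at the ring stereocentre.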